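The compounds below may be only part of what the source reports. "The series", "measured", "known", "first", "only" and "open" are said of these compounds alone.

Measured in a toxicity assay on J774.A1 cells (Mus musculus) for cytotoxicity, read by SYBR Green assay, with a stated time of 1 h; a lower number here means that less compound is needed, a higher number that more compound is needed for the effect:

Compound 1 `CN(C)c1ccc2cc(-c3ccccc3Br)c(N)nc2c1`: 12000 nM
Compound 2 `CN(C)c1ccc2cc(-c3cc(Cl)ccc3Cl)c(N)nc2c1`: 9800 nM
Compound 3 `CN(C)c1ccc2cc(-c3ccc(Cl)c(Cl)c3)c(N)nc2c1`: 3200 nM

A higher number here means that more compound is needed before the cells are affected. Compound 1 belongs to the upper pair of these numbers: at 12000 nM, it lies within the usual scatter of compound 2, at 9800 nM, so the two cannot be told apart. The gap between compound 1 and compound 3, at 3200 nM, lies beyond the scatter, so the three compounds do not all behave alike.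

The next compound, compound 4 `CN(C)c1ccc2cc(-c3ccccn3)c(N)nc2c1`, keeps the core of compound 1 but carries pyridin-2-yl in place of 2-bromophenyl on an aromatic carbon. For the measured compounds named here, none of the measured compounds carries pyridin-2-yl, and no measured pair isolates a single change, so the expectation is a loose one. In this assay, no step beyond the scatter is expected, with a slight lean towards a higher number. The expected change is a 1.3-fold higher number from compound 1 to compound 4 (0.10 log units; within the scatter). The estimate for compound 4 is 15000 nM, with an expected range of 6000 nM to 40000 nM.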

Compound 4, half-maximal effective concentration: 2200 nM
Estimate against measurement, compound 4: 6.8-fold (0.83 log units) above; the measured number lies below the stated range.
By their numbers in this assay, from the lowest: compounds 4 and 3 (each within the scatter of the next); then compounds 2 and 1 (each within the scatter of the next).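

In this assay, putting pyridin-2-yl in place of 2-bromophenyl gives a 5.5-fold lower number from compound 1 to compound 4 (0.74 log units; beyond the scatter), so the group on this aromatic carbon, ortho to an amino group, can shift the number by more than the usual scatter, something no single-place step had yet shown. The group stays a six-membered aromatic ring, but the change removes the bromine and adds a ring nitrogen, which counts as a hydrogen-bond acceptor, and this one step cannot separate the effects of those two differences. No measurement here explains the lower number, so the step stands as an observation only.

The compounds shown leave open whether the lower number comes from losing the bromine or from gaining the ring nitrogen, a question that plain phenyl at this place could help to answer. They also leave open whether the location of the nitrogen within the ring matters, as a comparison of pyridin-2-yl with pyridin-3-yl and pyridin-4-yl would show, and how a phenyl ring carrying an amine or a carboxylic acid would behave.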